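Bromo in Place of Methyl on Two Different Cores

The compounds below may be only part of what the source reports. "The series", "measured", "known", "first", "only" and "open" are said of these compounds alone.

Measured compounds:
compound 1 `COC(=O)[C@@]1(C)CCC=C2[C@@H]1CC[C@@H](C)[C@]2(C)Cc1c(C)[nH]c2ccc(C)cc12`, 28000 nM
compound 2 `COC(=O)[C@@]1(C)CCC=C2[C@@H]1CC[C@@H](C)[C@]2(C)Cc1c(C)[nH]c2ccc(Br)cc12`, 15000 nM
compound 3 `COC(=O)[C@@]1(C)CC[C@@H]2C3=C1CC[C@@H](C)[C@]3(C)C[C@@H]1c3cccc(C)c3N[C@H]21`, 43000 nM

All three were tested in a functional assay on WiDr cells (Homo sapiens) for inhibition, read by sulforhodamine B assay, with a stated time of 48 h; on this read-out lower numbers stand for stronger inhibition of growth and higher numbers for weaker inhibition of growth. Compound 1 and compound 2 share one core and differ in one place: bromo in place of methyl on an aromatic carbon. That change gave a 1.9-fold lower number from compound 1 to compound 2 (0.27 log units; within the scatter). Compound 3 has a different core; how it differs from compound 1 is not broken down here. Compound 4 `COC(=O)[C@@]1(C)CC[C@@H]2C3=C1CC[C@@H](C)[C@]3(C)C[C@@H]1c3cccc(Br)c3N[C@H]21` is not yet measured and differs from compound 3 in one place: bromo in place of methyl on an aromatic carbon. This is the same kind of change as from compound 1 to compound 2, though the surroundings differ: in compound 4 the ring belongs to a fused or bridged system of five rings, ortho and meta to a fused ring, while in compound 2 it belongs to a system of two rings, meta and para to a fused ring. Because the earlier step was a 1.9-fold lower number from compound 1 to compound 2 (0.27 log units; within the scatter), a step of similar size is expected, a 1.7-fold lower number from compound 3 to compound 4 (0.24 log units; within the scatter). Compound 4 is therefore estimated at 25000 nM, likely between 10000 nM and 60000 nM.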

Compound 4, concentration for 50% growth inhibition: 54000 nM
Estimate against measurement, compound 4: 2.2-fold (0.33 log units) below, and the stated range covers the measured number.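

In this assay, bromo in place of methyl gave a 1.3-fold higher number from compound 3 to compound 4 (0.10 log units; within the scatter), so on the core of compound 3, as on the core of compound 1, the step stays small. Set side by side, the two steps do not differ by more than repeated measurements could: the same change on two cores in this assay, a 1.9-fold lower number (0.27 log units; within the scatter) from compound 1 to compound 2 and a 1.3-fold higher number (0.10 log units; within the scatter) from compound 3 to compound 4, 2.3-fold (0.37 log units) apart, within the scatter of two such steps. This shows that the swap produced no step beyond the scatter on either core, but with one pair per core it cannot show that the two cores truly respond alike.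

The compounds shown leave open whether an amine on this aromatic carbon would give a step beyond the scatter. They also leave open what a carboxylic acid in place of the methyl ester would do on either core.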